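Notes on the step from compound 2 to compound 4

This account rests on a few compounds, and the source may have more. Where it says the series, first, only, none or still open, it means among the compounds named here.

Measured so far in an assay on isolated protein for inhibition of lactase/phlorizin hydrolase (Rattus norvegicus), read by colorimetric assay; on this read-out higher numbers stand for weaker inhibition and lower numbers for stronger inhibition:
compound 1 `Cc1ccc(S(=O)(=O)Nc2ccc3c(c2)C(=O)N(Cc2ccccc2F)C3=O)cc1` gives 180000 nM
compound 2 `Cc1ccc(S(=O)(=O)Nc2ccc3c(c2)C(=O)N(Cc2ccc(Cl)cc2)C3=O)cc1` gives 155000 nM
compound 3 `Nc1ccc2c(c1)C(=O)N(CCNc1ccccc1)C2=O` gives > 200000 nM

The value of compound 3 is a limit of this assay, not a number. Among the two numbers, compound 2 holds the lower one; its nearest neighbour is compound 1, and the step of a 1.2-fold lower number from compound 1 to compound 2 (0.06 log units; within the scatter) lies within the scatter, so the two are not ordered against each other.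

Compound 4 `Cc1ccc(S(=O)(=O)Nc2ccc3c(c2)C(=O)N(CCCCBr)C3=O)cc1` is not yet measured. It differs from compound 2 as follows: 3-bromopropyl in place of 4-chlorophenyl on a saturated chain carbon bound to an amide-type nitrogen in a ring

For the measured compounds named here, the only measured step that touches this position is a 1.2-fold lower number from compound 1 to compound 2 (0.06 log units; within the scatter), which swaps one ring for another at the same saturated chain carbon and moves nothing beyond the scatter. Going by the values given here, for the exchange of a ring for a short chain no measured step exists, so the expectation rests on the flat picture given by compound 1 and compound 2 alone. The step of a 1.2-fold higher number from compound 2 to compound 4 (0.09 log units; within the scatter) is therefore expected to stay within the scatter. Compound 4 is estimated at 190000 nM, between 100000 nM and 360000 nM, with a real chance that only a limit is reported, as for compound 3 at the limit of > 200000 nM in this assay, at which 1 of the 3 values shown sits.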

Compound 4, half-maximal inhibitory concentration: > 200000 nM
Compound 4: only a limit was reported; the forecaster's own chance of this, stated with the estimate: 40%; middle value at least 1.0-fold (0.02 log units) from the limit.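

In this assay compound 4 gives > 200000 nM, which is a limit and not a number, and it is the first compound with the core of compound 1 to sit at that limit: the limit of > 200000 nM in this assay, at which 2 of the 4 values shown sit.

On these data alone, the two new steps, an at least 1.2-fold higher number from compound 2 to compound 4 (0.11 log units; that floor lies within the scatter) and an at least 1.1-fold higher number from compound 1 to compound 4 (0.04 log units; that floor lies within the scatter), are floors only, so neither establishes a loss on giving up the ring, and the true size of each step remains unknown. What is new is that this position, on a saturated chain carbon bound to an amide-type nitrogen in a ring, has now carried an open 4-bromobutyl chain as well as the two benzyl groups, and the open chain gives no sign of stronger inhibition, a question the ring-for-ring step could not address.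

Open, as far as these compounds go, is how far compound 4 lies past its limit, and whether the terminal bromine or the chain itself sets that result, which a plain butyl chain or a chain ending in an amine or a carboxylic acid would separate. Also open, from the compounds shown here alone, is whether any group at this position gives inhibition clearly stronger than compound 2 at 155000 nM.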